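A Second Chloro Group on the Shared Core

The source may report more compounds than this note shows. Statements on the series, on what has been measured and on what is new or still open speak of the compounds shown alone.

Compound 1 `COc1ccccc1S(=O)(=O)/C=C/c1ccccn1` gives 9070 nM in an assay on U2OS cells for activation of nuclear factor erythroid 2-related factor 2 (Homo sapiens), read by chemiluminescence, with a stated time of 6 h; a lower number here means that less compound is needed, a higher number that more compound is needed for the effect. Compound 2 `COc1ccccc1S(=O)(=O)/C=C/c1cccc(Cl)n1` carries chloro in place of hydrogen on an aromatic carbon, and in this assay compound 2 gives 1160 nM, which amounts to a 7.8-fold lower number from compound 1 to compound 2 (0.89 log units; beyond the scatter). Compound 3 `COc1ccccc1S(=O)(=O)/C=C/c1cccnc1Cl` has a core whose difference from compound 1 is not broken down here; in this assay compound 3 gives 849 nM, a figure within the scatter of compound 2. Going by the values given here, compound 4 `COc1ccccc1S(=O)(=O)/C=C/c1ccc(Cl)nc1Cl` carries chloro in place of hydrogen on an aromatic carbon, the same kind of change as the one leading to compound 2, though here the place is also meta to a chloro group and para to a large group, rather than meta to a large group. The step from compound 3 is expected to be a 2.1-fold lower number from compound 3 to compound 4 (0.33 log units; beyond the scatter), smaller than a 7.8-fold lower number from compound 1 to compound 2 (0.89 log units; beyond the scatter) because compound 3 already stands at 849 nM. Compound 4 is therefore estimated at 400 nM, between 150 nM and 1200 nM.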

Compound 4, half-maximal effective concentration: 178 nM
Beside the measured number, compound 4's estimate is 2.2-fold (0.35 log units) above it, and the stated range covers the measured number.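

The step of a 4.8-fold lower number from compound 3 to compound 4 (0.68 log units; beyond the scatter) in this assay shows chloro in place of hydrogen on an aromatic carbon lowering the number on a second core. The size of the step carries over between the two cores as far as these pairs can tell: the same change on two cores in this assay, a 7.8-fold lower number (0.89 log units; beyond the scatter) from compound 1 to compound 2 and a 4.8-fold lower number (0.68 log units; beyond the scatter) from compound 3 to compound 4, 1.6-fold (0.21 log units) apart, within the scatter of two such steps. Going by these compounds alone, this rests on only two pairs, with the chloro group in a different place on each core, so it does not show that the step would hold on other cores or at other places.

The compounds shown leave open whether a fluoro group, a methyl group or an amine in the same place would lower the number as chloro does. They also leave open whether the step would survive a change to the methoxy group on the shared core.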